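Benzylamino nucleosides: weak antiproliferative series

This account rests on a few compounds, and the source may have more. Where it says the series, first, only, none or still open, it means among the compounds named here.

Measured compounds:
compound 1 `Cc1cccc(CNc2ncnc3c2ncn3[C@@H]2O[C@H](CO)[C@@H](O)[C@H]2O)c1` > 166000 nM
compound 2 `OC[C@H]1O[C@@H](n2cnc3c(NCc4ccc(Cl)cc4Cl)ncnc32)[C@H](O)[C@@H]1O` 106000 nM

Compound 1 gives only a limit in a functional assay on K562 cells (Homo sapiens) for antiproliferative activity, with a stated time of 72 h (a higher number here means a weaker inhibitor, a lower number a stronger inhibitor), > 166000 nM, and that limit is described as the limit of > 166000 nM in this assay, at which 1 of the 2 values shown sits. Among the measured compounds shown here, compound 2 is therefore the only member with a number, 106000 nM in this assay. For the measured compounds named here, the one step in hand, an at least 1.5-fold lower number from compound 1 to compound 2 (0.19 log units; that floor lies within the scatter), rests on a limit and its floor lies within the scatter.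

Compound 3 `COc1cccc(CNc2ncnc3c2ncn3[C@@H]2O[C@H](CO)[C@@H](O)[C@H]2O)c1O` is the next member. It differs from compound 2 by 2-hydroxy-3-methoxyphenyl in place of 2,4-dichlorophenyl on a saturated chain carbon bound to a nitrogen on an aromatic ring. No measured step changes the aryl group in this way, and the only step shown, from compound 1 to compound 2, is itself too small to read. Compound 3 is accordingly expected to sit near compound 2, with a 1.3-fold higher number from compound 2 to compound 3 (0.12 log units; within the scatter) as a nominal step that does not rise above the scatter. Compound 3 is estimated at 140000 nM, with a range from 50000 nM to 400000 nM.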

Compound 3, half-maximal inhibitory concentration: 27900 nM
Estimate against measurement, compound 3: 5.0-fold (0.70 log units) above; measured number outside the range, below it.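

Among the compounds shown here, with 2-hydroxy-3-methoxyphenyl in place of 2,4-dichlorophenyl, this assay shows a 3.8-fold lower number from compound 2 to compound 3 (0.58 log units; beyond the scatter) as the first step in these compounds with a measured number at both ends, so the aryl group on a saturated chain carbon bound to a nitrogen on an aromatic ring does bear on the result. Against 3-methylphenyl, the same group gives an at least 5.9-fold lower number from compound 1 to compound 3 (0.77 log units; beyond the scatter) and that step is only a floor, resting on a limit: the limit of > 166000 nM in this assay, at which 1 of the 3 values shown sits. The entering group has a hydrogen-bond donor and acceptors that 2,4-dichlorophenyl lacks, but nothing measured here ties the step to them.

From the compounds shown here alone, the hydroxy and methoxy groups enter together, so their separate shares in the step remain open. Also open, going by these compounds, is how an aryl group with only one of them, or with an amine or a carboxylic acid in their place, would read in this assay here.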